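1H-1,2,4-triazol-1-yl in place of (2-aminobenzyl)oxy

The source may hold more compounds than are shown below. What is called first, only, known or untested is meant among the compounds shown, and "the series" means these compounds.

In a functional assay on SK-OV-3 cells (Homo sapiens) for inhibition, read by CCK-8 assay, with a stated time of 70 h (on this read-out higher numbers stand for weaker inhibition and lower numbers for stronger inhibition), compound 1 `Nc1ccccc1COc1ccc(OCCOCCNC2CCCC2)cc1` gives 14000 nM, and compound 2 `O=[N+]([O-])c1cccc(COc2ccc(OCCOCCNC3CCCC3)cc2)c1` gives 15400 nM. Among the compounds with values here, the only measured step, a 1.1-fold higher number from compound 1 to compound 2 (0.04 log units; within the scatter), leaves these two unranked, so compound 1 has the lower number on paper but no real lead over its one neighbour.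

Compound 3 `c1ncn(-c2ccc(OCCOCCNC3CCCC3)cc2)n1` departs further from compound 1, and the change is 1H-1,2,4-triazol-1-yl in place of (2-aminobenzyl)oxy on an aromatic carbon. The new group stands on an aromatic carbon of the shared core, and the rest of the molecule stays the same.

The measured step bears on this only in part. It exchanged 2-aminophenyl for 3-nitrophenyl and kept a six-membered aromatic ring of carbon only in that region. Within the data shown here, no measured compound lacks such a ring there, so the data do not size the removal of the whole group. A modest move towards weaker inhibition is therefore expected, with wide uncertainty in either direction.

In this assay the expected change is a 1.8-fold higher number from compound 1 to compound 3 (0.25 log units; within the scatter). For compound 3 the estimated value is 25000 nM, with an expected range from 9000 nM to 70000 nM.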

Compound 3, half-maximal inhibitory concentration: > 100000 nM
Compound 3 gave a limit, no number; the forecaster's own chance of this, stated with the estimate: 15%; at least 4.0-fold (0.60 log units) between middle value and limit.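

In this assay compound 3 gives > 100000 nM and this is a limit of the assay, not a number: the limit of > 100000 nM in this assay, at which 1 of the 3 values shown sits.

Even read as a limit, the result gives an at least 7.1-fold higher number from compound 1 to compound 3 (0.85 log units; beyond the scatter) and so sets this change apart from the earlier exchange of 2-aminophenyl for 3-nitrophenyl, which stayed within the scatter. Together, the two steps show that the group on this aromatic carbon, para to a large group, is not interchangeable: a six-membered aromatic ring of carbon only was retained in the earlier step, whereas replacing the whole (2-aminobenzyl)oxy group with 1H-1,2,4-triazol-1-yl moves the result to the limit of the assay.

The change alters the ring, the ring's link to the core and the group's size all at once, so the compounds shown do not tell which of these matters, and the true distance of compound 3 from compound 1 remains unknown beyond the limit. A plain benzyloxy group, a phenyl ring bound directly to the core or a 1H-1,2,4-triazol-1-yl carried on a methyleneoxy link would separate these parts of the change.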